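Replacing an amide with a cyclobutyl ester on a shared core

The source may report more compounds than this note shows. Statements on the series, on what has been measured and on what is new or still open speak of the compounds shown alone.

Compound 1 `CC(=O)C1=C(C)NC(=O)NC1c1ccsc1` gives 1% in an assay on membranes from HeLa cells for displacement of a labelled ligand from adenosine receptor A3 (Homo sapiens), read by scintillation counting, with a stated time of 180 min, tested at 1 uM; a higher number here means more inhibition at the concentration tested (going by the name of the read-out), a lower number less inhibition.
Compound 2 `CC1=C(C(=O)NC(C)C)C(c2ccoc2)NC(=O)N1` gives 3% in this assay.
Compound 3 `CC1=C(C(=O)NC(C)C)C(c2ccsc2)NC(=O)N1` gives 1% in this assay.

All three numbers sit within the scatter of one another, so none of the three can be called stronger or weaker. Compound 3 stands level with compound 1, with no change at the digits printed from compound 1 to compound 3 (within the scatter), and differs from compound 2 only by a number 2 percentage points lower from compound 2 to compound 3 (within the scatter).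

Compound 4 `CC1=C(C(=O)OC2CCC2)C(c2ccsc2)NC(=O)N1` is the unmeasured step from compound 3: cyclobutyloxy in place of isopropylamino on a carbonyl carbon. Within the data shown here, the one measured step at this carbonyl carbon, no change at the digits printed from compound 1 to compound 3 (within the scatter), was flat, and no measured pair swaps the amide for an ester. The expected step is therefore a number 1 percentage points higher from compound 3 to compound 4 (within the scatter), none beyond the scatter. Compound 4 is estimated at 2%, expected between -5% and 12%.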

Compound 4, a percentage reported as inhibition, at one concentration (the size of the read-out at that concentration, not a potency): 3%
Compound 4: the middle estimate sits 1 percentage points below what was measured; the range from low to high includes it.
By their numbers in this assay, from the lowest: compounds 1, 3, 2 and 4 (each within the scatter of the next).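

In this assay the cyclobutyloxy group in place of isopropylamino on this carbonyl carbon gives a number 2 percentage points higher from compound 3 to compound 4 (within the scatter) and so brings in an ester, a four-membered ring and the loss of the amide hydrogen without leaving the scatter. Against methyl at the same carbon, cyclobutyloxy gives a number 2 percentage points higher from compound 1 to compound 4 (within the scatter) and so three different groups here now read alike. Nothing measured here offers an explanation for this flat result. On these data alone, whether a carboxylic acid or a benzyl ester on this carbonyl carbon would move the number beyond the scatter stays open. So does whether cyclobutyloxy reads the same with furan-3-yl in place of thiophen-3-yl.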